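The compounds below may be only part of what the source reports. "The series", "measured", "known", "first", "only" and "open" are said of these compounds alone.

In a functional assay on OVCAR-3 cells (Homo sapiens) for antiproliferative activity, read by WST assay, with a stated time of 72 h, in the absence of a further agent (a lower number here means a stronger inhibitor, a higher number a weaker inhibitor), compound 1 (`CCCCCCCCCCc1c(C)c(CCCCCCCCCC)c2[n+](c1C)CCC2`) gives 600 nM, compound 2 (`CCCCCCCC/C=C\c1c(C)c(/C=C\CCCCCCCC)c2[n+](c1C)CCC2`) gives 1100 nM and compound 3 (`CCCCCCCCCCc1c(C)c(CCCCCCCCCC)c2[n+](c1C)CCCC2`) gives 1700 nM as its result. All three carry two long side chains on a related core. Compound 2 has the middle number of the three, but its gaps to compound 1 and to compound 3 both lie within the usual scatter of repeated measurements, so it cannot be ranked against either.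

Compound 4 (`CCCCCCCC/C=C/c1c(C)c(/C=C/CCCCCCCC)c2[n+](c1C)CCC2`) has the same atoms and bonds as compound 2 and differs only in configuration as drawn (the two compounds have the same atoms and bonds and differ only in configuration as drawn: 2 of 2 stereo elements differ; a double bond is drawn Z in compound 2 and E in compound 4; a double bond is drawn Z in compound 2 and E in compound 4) in its two double bonds. Each double bond is drawn Z in compound 2 and E in compound 4. Going by the values given here, no measured pair here shows what such a switch does, so there is no direct precedent to draw on. Among the compounds with values here, the only guide is the value of compound 2 itself, together with the modest spread of the three results. No change beyond the scatter is therefore expected, and the estimated shift is a 1.1-fold lower number from compound 2 to compound 4 (0.04 log units; within the scatter) in size. Compound 4 is expected to give about 1000 nM in this assay, with an estimated range of 400 nM to 2500 nM around that figure.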

Compound 4, half-maximal inhibitory concentration: 800 nM
Compound 4: the middle estimate sits 1.3-fold (0.10 log units) above what was measured, within the range that was stated.
By their numbers in this assay, from the lowest: compounds 1, 4, 2 and 3 (each within the scatter of the next, the first and the last beyond it).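

Going by these compounds alone, this pair is the first in the set to isolate a single kind of structural difference: nothing enters or leaves, and both double bonds are drawn Z in compound 2 and E in compound 4. In this assay the switch gives a 1.4-fold lower number from compound 2 to compound 4 (0.14 log units; within the scatter), so the two compounds cannot be told apart in this read-out, and changing the configuration of both double bonds together has no effect beyond the scatter. The comparison is a direct one, as only one kind of difference is available to account for any gap between the two: the fact that compounds 2 and 4 differ only in the configuration as drawn

Going by these compounds, both double bonds change together in this pair, so it remains open whether switching only one of them would give the same result, and whether the switch would behave alike on the core of compound 3. On these data alone, it is also open how the side chains would respond to a different kind of group, such as an amine or a carboxylic acid, in place of part of the long carbon chain.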